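Benzoyl on the Amino Group of Compound 2

The source may hold more compounds than are shown below. What is called first, only, known or untested is meant among the compounds shown, and "the series" means these compounds.

Compound 1 `Nc1ncn(C/C=C2\OC(=O)C(OCc3ccccc3)=C2OCc2ccccc2)c(=O)n1` is the only one of the three measured compounds to give a number in a functional assay on HeLa cells (Homo sapiens) for inhibition, read by MTT assay, with a stated time of 72 h (a higher number here means a weaker inhibitor, a lower number a stronger inhibitor), where compound 1 reaches 5910 nM. Compound 2 `Nc1ccn(C[C@H](O)[C@H]2OC(=O)C(OCc3ccccc3)=C2OCc2ccccc2)c(=O)n1` gives in this assay only a limit of the assay, > 100000 nM, not a number. Compound 3 `NC1(CCn2cc(F)c(=O)[nH]c2=O)OC(=O)C(OCc2ccccc2)=C1OCc1ccccc1` likewise gives only a limit in this assay, > 100000 nM. So compound 2 stands at the limit of > 100000 nM in this assay, at which 2 of the 3 values shown sit, with no numerical value of its own. Compound 4 `O=C1O[C@H]([C@@H](O)Cn2ccc(NC(=O)c3ccccc3)nc2=O)C(OCc2ccccc2)=C1OCc1ccccc1` differs from compound 2 by benzoyl in place of hydrogen on a nitrogen on an aromatic ring. Within the data shown here, no measured step covers this change, so the expected step of an at least 1.1-fold lower number from compound 2 to compound 4 (0.04 log units; that floor lies within the scatter) is none beyond the scatter, with the result most likely remaining at the limit. Compound 4 is therefore expected to give about 90000 nM in this assay, within 20000 nM to 300000 nM.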

Compound 4, half-maximal inhibitory concentration: 35900 nM
Compound 4: middle estimate off by 2.5-fold (0.40 log units), on the high side, and the stated range covers the measured number.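

Changing amino to benzamido gives an at least 2.7-fold lower number from compound 2 to compound 4 (0.44 log units; beyond the scatter) in this assay. Among these compounds, this is the first sign that the group on this nitrogen can change the result, and it shows that benzoyl can stand in place of hydrogen here with a measurable number in return. Compound 2 gives only a limit of the assay, so the step is a floor and its true size stays unknown: the limit of > 100000 nM in this assay, at which 2 of the 4 values shown sit.

The compounds shown leave open whether the aromatic ring of benzoyl matters, or whether acetyl, which keeps the carbonyl without that ring, would do the same.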